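A few compounds are considered here, and "the series" means these few. Any claim that something is new, unique, unknown or untested is made for them only; others in the source may bear on it.

The series shares the core of compound 1 `O=C(NCCCOc1ccc2nc(O)ccc2c1)N(C1CCCCC1)C1CC1`, which in a functional assay on the whole organism for inhibition, with Rattus norvegicus as the target, at a dose of 30 mg/kg by the oral route (a higher number here means more inhibition at the dose given (going by the name of the read-out), a lower number less inhibition), gives 15%. Compound 2 `O=C(NCCCOc1ccc2nc(O)ccc2c1)N(C1CC1)[C@@H]1CCC[C@H]1O` gives 23% in this assay, and compound 3 `O=C(NCCCOc1ccc2nc(O)ccc2c1)N(C1CC1)[C@@H]1CCC[C@@H](O)C1` gives 0%. Compound 3 stands lowest of the three numbers: the step of a number 15 percentage points lower from compound 1 to compound 3 (beyond the scatter) and the step of a number 23 percentage points lower from compound 2 to compound 3 (beyond the scatter) both place it beyond the scatter below the other two, while the step of a number 8 percentage points higher from compound 1 to compound 2 (within the scatter) stays within the scatter.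

Compound 4 `O=C(NCCCOc1ccc2nc(O)ccc2c1)N(C1CC1)[C@H]1CC[C@H](O)CC1` differs from compound 3 in one place: 4-hydroxycyclohexyl in place of 3-hydroxycyclohexyl on an amide-type nitrogen. For the measured compounds named here, no measured step tests this exact change. The nearest are a number 15 percentage points lower from compound 1 to compound 3 (beyond the scatter), where hydroxy in place of hydrogen on a saturated ring carbon lowered the read-out, and a number 23 percentage points lower from compound 2 to compound 3 (beyond the scatter), where 3-hydroxycyclohexyl in place of 2-hydroxycyclopentyl lowered it further. Both steps that end at compound 3 went down, and compound 4 keeps a hydroxycyclohexyl on the amide-type nitrogen, so its number is expected to stay close to that of compound 3. The step is therefore expected to be small, a number 8 percentage points higher from compound 3 to compound 4 (within the scatter), with no shift beyond the scatter foreseen in this assay. Compound 4 is estimated at 8%, in a range from 0% to 25%.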

Compound 4, a percentage reported as inhibition, in the whole organism at one dose (the size of the read-out at that dose, not a potency): 7%
Estimate against measurement, compound 4: 1 percentage points above; the range from low to high includes it.
By their numbers in this assay, from the lowest: compounds 3, 4, 1 and 2 (each within the scatter of the next, the first and the last beyond it).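

In this assay, for the compounds shown here, the change from 3-hydroxycyclohexyl to 4-hydroxycyclohexyl on the amide-type nitrogen is the first direct test of where the hydroxy sits on the six-membered ring, and the step (a number 7 percentage points higher from compound 3 to compound 4 (within the scatter)) does not separate the two groups. Compared with the unsubstituted cyclohexyl group, the new hydroxycyclohexyl group also gives no clear separation (a number 8 percentage points lower from compound 1 to compound 4 (within the scatter)), whereas the corresponding step to compound 3 was beyond the scatter, so that earlier drop does not recur with the hydroxy on the other ring position. The 2-hydroxycyclopentyl group remains apart from the new group (a number 16 percentage points lower from compound 2 to compound 4 (beyond the scatter)), which means that both hydroxycyclohexyl compounds now lie beyond the scatter below compound 2.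

The compounds shown leave open whether an amine or a carboxylic acid in place of the hydroxy on the cyclohexyl ring, or a hydroxymethyl group at the same ring carbon, would read differently at this position, and whether the other stereoisomers of the 4-hydroxycyclohexyl group would match compound 4. Nothing at hand gives a reason for these numbers.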